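A few compounds are considered here, and "the series" means these few. Any claim that something is new, unique, unknown or untested is made for them only; others in the source may bear on it.

In an ADME assay on HEK293 cells (Homo sapiens) for inhibition, read by MTT assay, with stated times of 18 h and 4 h (a lower number here means a stronger inhibitor, a higher number a weaker inhibitor), compound 1 (`CCCCCCCCCCCCCCCCOP(=O)(O)OCCSC(=S)N1CCCCCC1`) gives > 100000 nM, which is a limit of the assay and not a number. Compound 1 therefore stands at the limit of > 100000 nM in this assay, at which 1 of the 3 values shown sits. Compound 2 (`CCCCCCCCCCOP(=O)(O)OCCSC(=S)N1CCCCCC1`) gives 70000 nM and compound 3 (`CCCCCCCCOP(=O)(O)OCCSC(=S)N1CCCCC1`) gives 69000 nM, two values within the scatter of each other.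

Compound 4 (`CCCCCCCCCCCCCCCCOP(=O)(O)OCCSC(=S)N1CCN(C)CC1`) has not yet been measured. It keeps the rest of compound 1 and differs from it at a single place: 4-methylpiperazin-1-yl in place of azepan-1-yl on a thiocarbonyl carbon.

Within the data shown here, only one measured step is available, and it bears on this change only indirectly. That step, an at least 1.4-fold lower number from compound 1 to compound 2 (0.15 log units; that floor lies within the scatter), alters the chain and leaves the group on the thiocarbonyl carbon untouched. Its floor also lies within the scatter, so it sets no size for the exchange in compound 4. Among the measured compounds shown here, no measured step covers this exchange, and the data give no direction for it. Nothing beyond the scatter is therefore expected in this assay, and compound 4 is expected to remain close to the limit reached by compound 1, possibly returning only a limit itself. The expected step is a number no higher from compound 1 to compound 4 (the limit leaves the size open). The estimate for compound 4 is 100000 nM, with an expected range from 45000 nM to 220000 nM.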

Compound 4, half-maximal inhibitory concentration: > 100000 nM
Compound 4: only a limit was reported (the forecaster's own chance of this, stated with the estimate: 55%); the middle value lies on the limit itself.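

In this assay compound 4 gives > 100000 nM, which is a limit of the assay and not a number. Compound 1 also stands at a limit, so no step can be read between compound 1 and compound 4. The compounds shown leave open whether 4-methylpiperazin-1-yl in place of azepan-1-yl on a thiocarbonyl carbon alters the number in this assay, and in which direction.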